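The compounds below may be only part of what the source reports. "The series", "measured", "known", "first", "only" and "open" are said of these compounds alone.

Measured in an in vitro ADME assay on microsomes from liver (Homo sapiens) for metabolic stability, read by LC-MS, tested at 1 uM; a lower number here means slower removal, a higher number faster removal of the compound:
Compound 1 `CCCS(=O)(=O)c1cccc(C#Cc2cc(Cl)ccc2OCC(=O)O)c1`: 11 mL.min-1.g-1
Compound 2 `COCCNS(=O)(=O)c1ccc(C)c(C#Cc2cc(Cl)ccc2OCC(=O)O)c1`: < 10 mL.min-1.g-1 (a limit of the assay, not a number)

Compound 2 has no exact number in this assay, only a limit: the limit of < 10 mL.min-1.g-1 in this assay, at which 1 of the 2 values shown sits. Compound 3 `Cc1ccc(S(C)(=O)=O)cc1C#Cc1cc(Cl)ccc1OCC(=O)O` carries methyl in place of (2-methoxyethyl)amino on a sulfonyl sulfur. Among the compounds with values here, no measured pair shows what such a change does. Within the data shown here, the expectation therefore leans on compound 1, which gives 11 mL.min-1.g-1, the only exact number available. The expected change is no larger than the usual scatter, with neither direction favoured: a step that the limit leaves unreadable from compound 2 to compound 3. For compound 3 the estimated value is 9 mL.min-1.g-1, with an expected range of 5 mL.min-1.g-1 to 17 mL.min-1.g-1.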

Compound 3, intrinsic clearance in microsomes: 14 mL.min-1.g-1
Compound 3: the middle estimate sits 1.6-fold (0.19 log units) below what was measured; low and high end bracket the measured number.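

In this assay, putting methyl in place of (2-methoxyethyl)amino on a sulfonyl sulfur gives an at least 1.4-fold higher number from compound 2 to compound 3 (0.14 log units; that floor lies within the scatter). Within the data shown here, this is the first measured pair for this change, but it sets only a floor and not a size, because compound 2 carries a limit of the assay rather than a number: the limit of < 10 mL.min-1.g-1 in this assay, at which 1 of the 3 values shown sits. The pair therefore shows no firm change at this position.

As far as these compounds go, how an ethyl chain or a plain amino group on the same sulfur would compare with methyl remains open.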